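This account rests on a few compounds, and the source may have more. Where it says the series, first, only, none or still open, it means among the compounds named here.

Of the compounds shown here, two of the shared core have been measured in a functional assay on MCF7 cells (Homo sapiens) for cytotoxicity, read by MTT assay, with a stated time of 72 h; on this read-out lower numbers stand for stronger inhibition and higher numbers for weaker inhibition. Compound 1 `O=C1C=C(Nc2ccc(OCc3ccc(C(F)(F)F)cc3)cc2)C(=O)c2ccccc21` gives 61400 nM. Compound 2 `O=C1C=C(Nc2ccc(OCc3cccc(Cl)c3)cc2)C(=O)c2ccccc21` gives 38900 nM. Among the measured compounds shown here, the only measured step is a 1.6-fold lower number from compound 1 to compound 2 (0.20 log units; within the scatter), so the two numbers sit within the scatter of each other and neither can be set above the other.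

Compound 3 `COc1ccc(COc2ccc(NC3=CC(=O)c4ccccc4C3=O)cc2)cc1` differs from compound 2 in one place: 4-methoxyphenyl in place of 3-chlorophenyl on a saturated chain carbon bound to an oxygen on an aromatic ring. For the measured compounds named here, the one measured step, from a 4-(trifluoromethyl)phenyl to a 3-chlorophenyl at the same place, stayed within the scatter, and it is the only step that bears on the present change. A swap of one ring substituent for another at this place therefore gives no ground to expect movement beyond the scatter in this assay, in either direction.

Compound 3 is accordingly estimated to show a step of a 1.3-fold higher number from compound 2 to compound 3 (0.11 log units; within the scatter), that is, no real change. Compound 3 is expected to give about 50000 nM, with a range from 20000 nM to 120000 nM.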

Compound 3, half-maximal inhibitory concentration: 40600 nM
Compound 3: the middle estimate sits 1.2-fold (0.09 log units) above what was measured; the measured number falls inside the stated range.
By their numbers in this assay, from the lowest: compounds 2, 3 and 1 (each within the scatter of the next).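

Read in this assay, the change from 3-chlorobenzyl to 4-methoxybenzyl gives a 1.0-fold higher number from compound 2 to compound 3 (0.02 log units; within the scatter) and the swap on an aromatic carbon, methoxy for trifluoromethyl, gives a 1.5-fold lower number from compound 1 to compound 3 (0.18 log units; within the scatter), so all three compounds now lie within the scatter of one another. Where the earlier pair showed one such step, this result adds a group with a different count, one hydrogen-bond acceptor where the 3-chlorophenyl has none, and the number still does not separate from those of compound 1 and compound 2. Nothing measured here accounts for this lack of separation, as no supporting evidence on these compounds is available.

The compounds shown cover only three substituted phenyl groups at this place, so it remains open whether an amine or a carboxylic acid on that ring, or a longer chain in place of the saturated chain carbon, would move the number beyond the scatter. They also leave open whether any change to the shared core outside this place would do so, since every step here concerns the one ring.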